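From amino side chain to (pyrrolidin-2-yl)methoxy

The source may report more compounds than this note shows. Statements on the series, on what has been measured and on what is new or still open speak of the compounds shown alone.

In a functional assay on MCF7 cells (Homo sapiens) for inhibition, read by fluorescence, with a stated time of 72 h (a lower number here means a stronger inhibitor, a higher number a weaker inhibitor), compound 3 `CC(C)[C@@H](CO)Nc1nc(NC(=N)N)c2ncn(C(C)C)c2n1` gives 2100 nM as the lowest of the two numbers in the series, and compound 2 `CC(C)[C@H](CO)Nc1nc(NC(=N)N)c2ncn(C(C)C)c2n1` gives 10500 nM as the other. Compound 1 `CC[C@@H](N)COc1nc(NC(=N)N)c2ncn(C(C)C)c2n1` reads > 100000 nM as a limit of the assay and not a number.

Among the measured compounds shown here, the next structure is compound 4 `CC(C)n1cnc2c(NC(=N)N)nc(OC[C@H]3CCCN3)nc21`, and the change (pyrrolidin-2-yl)methoxy in place of (1-(hydroxymethyl)-2-methylpropyl)amino on an aromatic carbon is its only difference from compound 3. The closest guide is the step of an at least 47-fold lower number from compound 1 to compound 3 (1.67 log units; beyond the scatter) with the amino side chain entering in place of 2-aminobutoxy. The step of an at least 9.5-fold lower number from compound 1 to compound 2 (0.97 log units; beyond the scatter) runs the same way. Compound 4 returns to an oxygen-linked group of the kind compound 1 carries, so these steps suggest a loss rather than a gain. The step of a 5.0-fold lower number from compound 2 to compound 3 (0.70 log units; beyond the scatter) concerns configuration alone and bears less on this change.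

A higher number is therefore expected in this assay with the estimated step of a 12-fold higher number from compound 3 to compound 4 (1.08 log units; beyond the scatter) as a working figure of large size. Compound 4 is estimated at 25000 nM with an expected range of 4000 nM to 100000 nM for the measurement.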

Compound 4, half-maximal inhibitory concentration: > 100000 nM
Compound 4 ended at the assay's limit; the forecaster's own chance of this, stated with the estimate: 30%; middle value at least 4.0-fold (0.60 log units) away from the limit.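

In this assay compound 4 gives > 100000 nM, which is a limit of the assay and not a number. On the aromatic carbon between two ring nitrogen atoms, (pyrrolidin-2-yl)methoxy gives an at least 47-fold higher number from compound 3 to compound 4 (1.67 log units; beyond the scatter) and an at least 9.5-fold higher number from compound 2 to compound 4 (0.97 log units; beyond the scatter), so the loss holds against (1-(hydroxymethyl)-2-methylpropyl)amino in both drawn configurations. The step from compound 1 to compound 4 cannot be read, and the ring-bearing and open-chain oxygen-linked side chains of these two compounds cannot be ordered: the limit of > 100000 nM in this assay, at which 2 of the 4 values shown sit.

The change replaces the linking atom and the rest of the side chain together, so the shown compounds do not separate the two. A (pyrrolidin-2-yl)methylamino group, or a hydroxyl-bearing chain linked through oxygen, on the same core would bear directly on that question.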